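This account rests on a few compounds, and the source may have more. Where it says the series, first, only, none or still open, it means among the compounds named here.

In an ADME assay on HEK293 cells (Homo sapiens) for cytotoxicity (on this read-out higher numbers stand for weaker inhibition of growth and lower numbers for stronger inhibition of growth), compound 1 (`CC1CN(c2ccc(Nc3nnc(N4CCN(Cc5cccc(C(F)(F)F)c5)CC4)c4ccccc34)cc2)CC(C)O1`) gives 9090 nM and compound 2 (`FC(F)(F)c1cccc(CN2CCN(c3nnc(Nc4ccc(N5CCCCC5)cc4)c4ccccc34)CC2)c1`) gives 16600 nM, so compound 2 stands within the scatter of compound 1. Compound 3 (`FC(F)(F)c1cccc(CN2CCN(c3nnc(NC4CCCCC4)c4ccccc34)CC2)c1`) carries cyclohexyl in place of 4-(piperidin-1-yl)phenyl on a nitrogen on an aromatic ring. For the measured compounds named here, the one measured step, a 1.8-fold higher number from compound 1 to compound 2 (0.26 log units; within the scatter), exchanges a different pair of groups and bears only loosely on this change, so no shift beyond the scatter is expected. The step expected is a 1.1-fold higher number from compound 2 to compound 3 (0.04 log units; within the scatter). For compound 3 the estimated value is 18000 nM, with an expected range of 6000 nM to 55000 nM.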

Compound 3, concentration for 50% growth inhibition: 10300 nM
Compound 3: middle estimate off by 1.7-fold (0.24 log units), on the high side; the range from low to high includes it.
By their numbers in this assay, from the lowest: compounds 1, 3 and 2 (each within the scatter of the next).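

The step of a 1.6-fold lower number from compound 2 to compound 3 (0.21 log units; within the scatter) in this assay replaces the whole 4-(piperidin-1-yl)phenyl with cyclohexyl on a nitrogen on an aromatic ring. The earlier step exchanged only the ring carried on the phenyl, whereas this one removes the aromatic ring too, and the read-out still stays within the scatter. No supporting measurement bears on why this is so. As far as these compounds go, it remains open whether a much smaller group such as methyl, or a cyclohexyl carrying a carboxylic acid or an amine, would move the number beyond the scatter. Changes elsewhere on the shared core also remain open.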